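Amino in Place of Methyl: An Untested Step

The source may report more compounds than this note shows. Statements on the series, on what has been measured and on what is new or still open speak of the compounds shown alone.

compound 1 `Fc1ccc(C2(c3ccc(F)cc3)CNC(c3cccc(Cl)c3)=N2)cc1`: 5.4 nM
compound 2 `Cc1cccc(C2=NC(c3ccc(F)cc3)(c3ccc(F)cc3)CN2)c1`: 30 nM

Of the compounds shown here, two have been measured in an assay on LM cells for displacement of a labelled ligand from Neuropeptide Y receptor type 5 (Homo sapiens); a higher number here means a weaker inhibitor, a lower number a stronger inhibitor. Compound 1 `Fc1ccc(C2(c3ccc(F)cc3)CNC(c3cccc(Cl)c3)=N2)cc1` gives 5.4 nM. Among the measured compounds shown here, compound 2 `Cc1cccc(C2=NC(c3ccc(F)cc3)(c3ccc(F)cc3)CN2)c1` gives 30 nM, the higher of the two numbers; the only step between them is a 5.6-fold higher number from compound 1 to compound 2 (0.74 log units; beyond the scatter). Compound 3 `Nc1cccc(C2=NC(c3ccc(F)cc3)(c3ccc(F)cc3)CN2)c1` has not been measured. It differs from compound 2 by amino in place of methyl on an aromatic carbon. For the measured compounds named here, no measured step bears directly on this change: the single known step, a 5.6-fold higher number from compound 1 to compound 2 (0.74 log units; beyond the scatter), swaps chloro for methyl on an aromatic carbon and says nothing about amino. What it does show is that a change at this place can move the number beyond the scatter. With no closer guide, the step for compound 3 is expected to be a 2.0-fold higher number from compound 2 to compound 3 (0.30 log units; within the scatter). Compound 3 is estimated at 60 nM, with a range of 15 nM to 300 nM.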

Compound 3, half-maximal inhibitory concentration: 300 nM
Compound 3: middle estimate off by 5.0-fold (0.70 log units), on the low side; the measured number falls inside the stated range.
By their numbers in this assay, from the lowest: compound 1; then compound 2; then compound 3.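

Amino proves a poor replacement at this place, meta to a large group: in this assay the change gives a 10-fold higher number from compound 2 to compound 3 (1.00 log units; beyond the scatter) and so carries the number well beyond the scatter. It brings in 1 hydrogen-bond donor and 1 hydrogen-bond acceptor where methyl has none, and set against chloro it gives a 56-fold higher number from compound 1 to compound 3 (1.74 log units; beyond the scatter) as the widest step among these compounds, so the three groups now order the series as chloro, then methyl, then amino.

From the compounds shown here alone, whether a hydroxyl or a methoxy group at this place would stay near chloro or fall toward amino remains open. So does whether an acetamide, which keeps the nitrogen on the ring, or a dimethylamino group, would recover any of the loss.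

Nothing shown here accounts for the size of these steps.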